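Aryl swap on the shared core: compound 2 to compound 4

A few compounds are considered here, and "the series" means these few. Any claim that something is new, unique, unknown or untested is made for them only; others in the source may bear on it.

Measured so far in a functional assay on Mahlavu cells (Homo sapiens) for inhibition, read by sulforhodamine B assay, with a stated time of 72 h; a lower number here means a stronger inhibitor, a higher number a weaker inhibitor:
- compound 1 `CC(c1ccc(-c2ccccc2)c(F)c1)c1nnc2n1N=C(c1ccc(Cl)cc1)CS2`: compound 1 gives 6100 nM
- compound 2 `CC(c1ccc(-c2ccccc2)c(F)c1)c1nnc2n1N=C(c1ccc(Cl)cc1Cl)CS2`: compound 2 gives 6600 nM
- compound 3 `CC(C)Cc1ccc(C(C)c2nnc3n2N=C(c2ccc(OC(F)(F)F)cc2)CS3)cc1`: compound 3 gives 9100 nM

Compound 2 sits second highest of the three numbers in this assay, and its nearest neighbour is compound 1, with compound 3 furthest away; both gaps lie within the scatter, so the three compounds cannot be placed in any order of strength on these data.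

Compound 4 `COc1ccc(C2=Nn3c(nnc3C(C)c3ccc(-c4ccccc4)c(F)c3)SC2)cc1` is the next entry. The change from compound 2 is 4-methoxyphenyl in place of 2,4-dichlorophenyl on a carbon with a double bond to nitrogen.

For the measured compounds named here, only one single-point step has been measured, a 1.1-fold higher number from compound 1 to compound 2 (0.03 log units; within the scatter), and it was within the scatter. That step concerns a chloro added to the same aryl group, not its replacement, so it bears on the present change only loosely. Compound 3, which carries a different aryl group at this position together with a different other part, gives a number within the scatter of compound 2. Going by the values given here, nothing measured so far points to a change beyond the scatter in this assay for compound 4.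

Compound 4 is therefore expected to give about 7000 nM in this assay, within a range of 3000 nM to 16000 nM.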

Compound 4, half-maximal inhibitory concentration: 5800 nM
Compound 4: the middle estimate sits 1.2-fold (0.08 log units) above what was measured, and the stated range covers the measured number.
By their numbers in this assay, from the lowest: compounds 4, 1, 2 and 3 (each within the scatter of the next).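

The exchange of the whole aryl group gives a 1.1-fold lower number from compound 2 to compound 4 (0.06 log units; within the scatter) in this assay and the exchange of methoxy for chloro gives a 1.1-fold lower number from compound 1 to compound 4 (0.02 log units; within the scatter) on the same shared core. On this core, the carbon with a double bond to nitrogen therefore carries 4-methoxyphenyl, which brings one hydrogen-bond acceptor, and 2,4-dichlorophenyl, which brings none, with no difference that can be read in this assay. No measurement on hand bears on why these numbers stay together.

From the compounds shown here alone, it remains open whether any group at this position moves the number beyond the scatter. An amine or a carboxylic acid on the aryl group, or cyclohexyl in place of it, would test how far this insensitivity extends.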